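Thiophen-3-yl in place of cyclohexyl on the shared core

This account rests on a few compounds, and the source may have more. Where it says the series, first, only, none or still open, it means among the compounds named here.

Compound 3 `COC(=O)c1nc(C2CCCCC2)n(-c2ccc(C(F)(F)F)cc2)n1` sits at the edge of what a functional assay on NPC-TW01 cells (Homo sapiens) for inhibition, read by MTT assay, with a stated time of 72 h (a lower number here means a stronger inhibitor of growth, a higher number a weaker inhibitor of growth), can report. In this assay compound 3 gives only a limit, > 100000 nM, and no number. Compound 1 `COC(=O)c1nc(C)n(-c2ccc(C(F)(F)F)cc2)n1` is in the same position, and in this assay compound 1 gives only the limit > 100000 nM. The step that the two limits leave unreadable from compound 1 to compound 3 is thus not readable in size, as the limit of > 100000 nM in this assay, at which 2 of the 3 values shown sit, records. Among the measured compounds shown here, compound 2 `COC(=O)c1nc(-c2ccsc2)n(-c2ccc(F)cc2)n1` is the one analogue that carries the thiophen-3-yl group, and in this assay compound 2 gives 10700 nM, a number rather than a limit.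

Compound 4 `COC(=O)c1nc(-c2ccsc2)n(-c2ccc(C(F)(F)F)cc2)n1` is not yet measured. It differs from compound 3 by thiophen-3-yl in place of cyclohexyl on an aromatic carbon. For the measured compounds named here, no measured step bears directly on this exchange; the only measured step concerns methyl against cyclohexyl at the same place and its size is hidden by the limit. Going by the values given here, the one foothold is compound 2, whose thiophen-3-yl group on a differently substituted core gives 10700 nM. On that basis compound 4 is expected to come off the limit and is estimated at 25000 nM, within 6000 nM to 100000 nM. The expected step of an at least 4.0-fold lower number from compound 3 to compound 4 (0.60 log units; beyond the scatter) is toward stronger inhibition, with a real chance that only a limit is again returned.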

Compound 4, concentration for 50% growth inhibition: 34900 nM
Beside the measured number, compound 4's estimate is 1.4-fold (0.14 log units) below it, and the stated range covers the measured number.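

In this assay, among the compounds shown here, thiophen-3-yl on this aromatic carbon gives the only number among the trifluoromethyl compounds, with an at least 2.8-fold lower number from compound 3 to compound 4 (0.45 log units; beyond the scatter) and an at least 2.8-fold lower number from compound 1 to compound 4 (0.45 log units; beyond the scatter). Compound 1 and compound 3 each hold only a limit of the assay, so these two steps are floors and the step between compound 1 and compound 3 cannot be read: the limit of > 100000 nM in this assay, at which 2 of the 4 values shown sit.

The aryl substituent now also has a readable step with thiophen-3-yl held constant, trifluoromethyl in place of fluoro giving a 3.3-fold higher number from compound 2 to compound 4 (0.51 log units; beyond the scatter), so in this pair fluoro goes with the stronger growth inhibition in this assay.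

Open, from the compounds shown here alone, is whether the gain at this place belongs to an aromatic ring as such or to the thiophen-3-yl group in particular, a question that phenyl at the same carbon would address. Also open, going by these compounds, is whether the methoxycarbonyl group is needed for any number to be read at all, which a carboxylic acid or a primary amide in its place on the shared core would test.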